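Working notes: amide swap from compound 3 to compound 4

The compounds below may be only part of what the source reports. "The series", "measured", "known", "first", "only" and "open" are said of these compounds alone.

Compound 1 `COc1ncc(-c2ccc3nccc(/C(C)=C/C(=O)N(C)CCO)c3c2)cc1NS(=O)(=O)c1ccc(F)cc1F`: 380 nM
Compound 2 `COc1ncc(-c2ccc3nccc(/C=C/C(=O)N4CCN(C)CC4)c3c2)cc1NS(=O)(=O)c1ccc(F)cc1F`: 220 nM
Compound 3 `COc1ncc(-c2ccc3nccc(/C(C)=C/C(=O)N4CCCC4)c3c2)cc1NS(=O)(=O)c1ccc(F)cc1F`: 390 nM

In a functional assay on U-87MG ATCC cells for inhibition, with U-87 MG (Homo sapiens) as the target, read by sulforhodamine B assay, with a stated time of 72 h (on this read-out lower numbers stand for stronger inhibition of growth and higher numbers for weaker inhibition of growth), compound 3 gives 390 nM, which lies within the scatter of both other compounds. The next structure to be read is compound 4 `COc1ncc(-c2ccc3nccc(/C(C)=C/C(=O)N4CCC(O)CC4)c3c2)cc1NS(=O)(=O)c1ccc(F)cc1F`, which has 4-hydroxypiperidin-1-yl in place of pyrrolidin-1-yl on a carbonyl carbon.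

The closest measured precedent is a 1.0-fold higher number from compound 1 to compound 3 (0.01 log units; within the scatter), a change on the same carbonyl carbon, with pyrrolidin-1-yl in place of (2-hydroxyethyl)(methyl)amino. The two remaining steps, a 1.7-fold lower number from compound 1 to compound 2 (0.24 log units; within the scatter) and a 1.8-fold higher number from compound 2 to compound 3 (0.25 log units; within the scatter), also alter the group on the carbonyl carbon, but they change the ethenyl chain as well and so bear on this case less directly. None of the three steps lies beyond the scatter, although 4-hydroxypiperidin-1-yl itself has not yet been tested in this set. On the strength of compound 1 and a 1.0-fold higher number from compound 1 to compound 3 (0.01 log units; within the scatter), no step beyond the scatter is expected in this assay, and no direction can be argued with confidence. The expected change is a 1.1-fold lower number from compound 3 to compound 4 (0.05 log units; within the scatter). For compound 4 the estimated value is 350 nM, with an expected range of 170 nM to 750 nM.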

Compound 4, concentration for 50% growth inhibition: 600 nM
Compound 4: the middle estimate sits 1.7-fold (0.23 log units) below what was measured, within the range that was stated.
By their numbers in this assay, from the lowest: compounds 2, 1, 3 and 4 (each within the scatter of the next, the first and the last beyond it).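

In this assay, the group on this carbonyl carbon now has three forms on the same 1-methylethenyl chain, and the new one, a six-membered ring bearing a hydroxy group, gives a 1.5-fold higher number from compound 3 to compound 4 (0.19 log units; within the scatter) and a 1.6-fold higher number from compound 1 to compound 4 (0.20 log units; within the scatter), so neither step from 4-hydroxypiperidin-1-yl to the earlier amides leaves the scatter. The set also gains its first step beyond the scatter, a 2.7-fold higher number from compound 2 to compound 4 (0.44 log units; beyond the scatter), but that step replaces the 4-methylpiperazin-1-yl amide and adds the 1-methyl group on the ethenyl chain together, so it cannot be assigned to either part alone. No supporting evidence on the origin of this gap is available.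

The compounds shown leave open how much of that gap belongs to the chain methyl and how much to the amide, a question that 4-methylpiperazin-1-yl on the 1-methylethenyl chain or 4-hydroxypiperidin-1-yl on the plain ethenyl chain would separate. Also open, on these data alone, is whether the flat response at this carbonyl carbon extends to morpholin-4-yl, to a primary amide or to a carboxylic acid in place of the amide.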